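The source may hold more compounds than are shown below. What is called first, only, known or untested is meant among the compounds shown, and "the series" means these compounds.

Measured compounds in an assay on isolated protein for inhibition of Rho-associated protein kinase 2 (Homo sapiens), read by scintillation counting, radiometric assay and 33P incorporation, with a stated time of 40 min, in the presence of a further agent that is not named here; a lower number here means a stronger inhibitor, a higher number a weaker inhibitor:
- compound 1 `COc1cccc(OCC(=O)Nc2cccc(NC(=O)c3ccc(N(C)C)cc3)c2)c1`: compound 1 gives 5740 nM
- compound 2 `CN(C)c1ccc(C(=O)Nc2cccc(NC(=O)COc3ccc4c(c3)OCCO4)c2)cc1`: compound 2 gives > 10000 nM, which is a limit of this assay and not a number
- compound 3 `Cc1ccc(C(=O)Nc2cccc(NC(=O)COc3ccc4c(=O)ccoc4c3)c2)cc1`: compound 3 gives 22 nM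

Compound 3 holds the lowest of the two numbers in this assay; the nearest is compound 1, and the gap between them is well beyond the usual scatter. For the measured compounds named here, the only measured step, an at least 1.7-fold higher number from compound 1 to compound 2 (0.24 log units; that floor lies within the scatter), changes the aryl on the oxygen on a saturated carbon and runs into (the limit of > 10000 nM in this assay, at which 1 of the 3 values shown sits), so only a floor is known for its size.

Compound 4 `Nc1cccc(C(=O)Nc2cccc(NC(=O)COc3ccc4c(=O)ccoc4c3)c2)c1` has not yet been measured. Its change from compound 3 is 3-aminophenyl in place of 4-methylphenyl on a carbonyl carbon. Going by the values given here, the measured step changes a different part of the shared core, the group on the oxygen on a saturated carbon, and no measured pair varies the 4-methylphenyl on the carbonyl carbon, so nothing in the numbers so far bears directly on this change. The expectation in this assay is therefore a step of no more than the usual scatter and without a clear direction, a 1.8-fold higher number from compound 3 to compound 4 (0.26 log units; within the scatter), kept wide to reflect the absence of a matched step. For compound 4 the estimated value in this assay is 40 nM, with a range from 10 nM to 200 nM.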

Compound 4, half-maximal inhibitory concentration: 58 nM
The estimate for compound 4 lay 1.5-fold (0.16 log units) below the measured number; the measured number falls inside the stated range.
By their numbers in this assay, from the lowest: compound 3; then compound 4; then compound 1. At a limit, above all of these: compound 2.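

In this assay, for the compounds shown here, the first measured step at the carbonyl carbon is a 2.6-fold higher number from compound 3 to compound 4 (0.42 log units; beyond the scatter) and shows that the number responds to a change on this ring, though only modestly: compound 4 still gives 58 nM with 3-aminophenyl, which brings a hydrogen-bond donor and a hydrogen-bond acceptor that 4-methylphenyl lacks. The step changes both the group and the number of its ring position, so it cannot be assigned to either one alone. Going by these compounds alone, nothing measured so far accounts for the size or direction of this step.

Still open, going by these compounds, is whether 4-aminophenyl or 3-methylphenyl on the same carbonyl carbon would sit with compound 3 or with compound 4, and whether a hydroxyl or a carboxylic acid in place of the amine would hold the number. Within the data shown here, also open is how far the group on the oxygen on a saturated carbon can be changed while keeping the number of compound 3 or compound 4, as no step on that group starts from either compound.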